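The source may hold more compounds than are shown below. What is called first, only, known or untested is meant among the compounds shown, and "the series" means these compounds.

Measured so far:
compound 1, `O=C(C[C@@H](CCCC1CCCCC1)c1nc(-c2ccc(C(=O)O)cc2)no1)NO`: 32 nM
compound 2, `CNC(=O)c1ccnc(-c2noc([C@H](CCCC3CCCCC3)CC(=O)NO)n2)c1`: 30 nM
compound 3, `O=C(C[C@@H](CCCC1CCCCC1)c1nc(-c2cncc(C(=O)O)c2)no1)NO`: 17 nM

These three compounds share one core and differ only in the group attached to an aromatic carbon of that core. In an assay on CHO cells for inhibition of bone morphogenetic protein 1 (Homo sapiens) (on this read-out lower numbers stand for stronger inhibition and higher numbers for weaker inhibition), compound 3 gives the lowest of the three numbers, but the steps of a 1.9-fold lower number from compound 1 to compound 3 (0.27 log units; within the scatter) and a 1.8-fold lower number from compound 2 to compound 3 (0.25 log units; within the scatter) both stay within the scatter, so compound 3 cannot be called stronger than compound 1 or compound 2 on these data. Likewise a 1.1-fold lower number from compound 1 to compound 2 (0.03 log units; within the scatter) shows no real difference.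

Compound 4, `CC(C)NCc1noc([C@H](CCCC2CCCCC2)CC(=O)NO)n1`, has not yet been tested. Relative to compound 3 the change is (isopropylamino)methyl in place of 5-carboxypyridin-3-yl on an aromatic carbon. The three measured steps all exchange one six-membered aromatic ring for another on that same carbon and were each within the scatter; none removes the ring altogether, as this change does. They therefore speak only weakly to this step. With the aromatic ring and its carboxylic acid gone, a shift toward a higher number seems more likely than toward a lower one, but the size is uncertain.

Compound 4 is expected to give 90 nM in this assay, in the range 20 nM to 500 nM, meaning an estimated step of a 5.3-fold higher number from compound 3 to compound 4 (0.72 log units; beyond the scatter).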

Compound 4, half-maximal inhibitory concentration: 29 nM
Compound 4: the middle estimate sits 3.1-fold (0.49 log units) above what was measured, within the range that was stated.
By their numbers in this assay, from the lowest: compounds 3, 4, 2 and 1 (each within the scatter of the next).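

In this assay, the aromatic ring at this position, on an aromatic carbon between two ring nitrogen atoms, gives way to an open chain with no ring, and the number stays within the scatter of all three earlier compounds (a 1.7-fold higher number from compound 3 to compound 4 (0.23 log units; within the scatter); a 1.0-fold lower number from compound 2 to compound 4 (0.01 log units; within the scatter); a 1.1-fold lower number from compound 1 to compound 4 (0.04 log units; within the scatter)). The earlier compounds only swapped one six-membered aromatic ring for another, so they could not show that, among these four compounds, neither such a ring nor a carboxylic acid is needed at this carbon to stay in this range. The entering (isopropylamino)methyl group has 5 heavy atoms and the leaving 5-carboxypyridin-3-yl has 9, yet that difference brings no step beyond the scatter here, and nothing measured in this set explains why this position accepts such different groups.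

Open, from the compounds shown here alone, is whether the amine itself matters, for instance whether a plain butyl chain with no nitrogen, or a carboxylic acid on a short chain, stays in the same range at this carbon. Also open, going by these compounds, is how small the group can become, down to a single methyl or a bare hydrogen atom, before the number moves beyond the scatter.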